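The compounds below may be only part of what the source reports. "The series", "measured", "known", "first", "only" and "open" are said of these compounds alone.

Measured so far in a functional assay on the whole organism (strain albino) for inhibition, with Rattus norvegicus as the target, read by paw edema, with stated times of 1 h and 2 h, at a dose of 20 mmol/kg by the intraperitoneal route; on this read-out lower numbers stand for less inhibition and higher numbers for more inhibition at the one dose given (going by the name of the read-out): compound 1 `N#CC1=C(NCN2CCCC2)N(c2ccccc2)C(=O)N2CCCCC(N3CCCC3)C12` gives 26.6%, and compound 2 `N#CC1=C(/N=C/Nc2ccccc2)N(c2ccccc2)C(=O)N2CCCCC(N3CCCC3)C12` gives 47.5%.

Going by the values given here, compound 2 stands highest of the two numbers so far. Among the compounds with values here, the one measured step, a number 20.9 percentage points higher from compound 1 to compound 2 (beyond the scatter), came with the exchange of a group of 7 heavy atoms with a five-membered non-aromatic ring for a group of 9 heavy atoms with a six-membered aromatic ring on a double-bonded ring carbon, a modest rise beyond the scatter.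

Compound 3 `N#CC1=C(/N=C/c2ccc([N+](=O)[O-])cc2)N(c2ccccc2)C(=O)N2CCCCC(N3CCCC3)C12` is not yet measured. It differs from compound 2 in one place: 4-nitrophenyl in place of anilino on a carbon with a double bond to nitrogen. The carbon with the double bond to nitrogen stays, and only the group attached to it changes. Within the data shown here, no measured step touches this change; the step from compound 1 to compound 2 altered a different part of the same side chain, so it gives no direction here. The expectation is therefore no clear step beyond the scatter, so that a number 2.5 percentage points lower from compound 2 to compound 3 (within the scatter) is expected to be small in either direction. Compound 3 is estimated at 45%, within a range from 28% to 62% in this assay.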

Compound 3, a percentage reported as inhibition, in the whole organism at one dose (the size of the read-out at that dose, not a potency): 80.9%
Beside the measured number, compound 3's estimate is 35.9 percentage points below it; the whole stated range lies below it.
By their numbers in this assay, from the lowest: compound 1; then compound 2; then compound 3.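

In this assay, the group on the carbon with a double bond to nitrogen turns out to matter a great deal: putting 4-nitrophenyl in place of anilino gives a number 33.4 percentage points higher from compound 2 to compound 3 (beyond the scatter), a large step where the earlier change in this side chain gave only a modest one. Taken from the start of the series, the whole side-chain change gives a number 54.3 percentage points higher from compound 1 to compound 3 (beyond the scatter), so compound 3 stands clearly above both other compounds and this carbon emerges as a place where the read-out responds strongly to the attached group. Nothing available here explains why this exchange goes with so much more inhibition of the paw edema.

This single exchange removes the anilino nitrogen and brings in the nitro group at the same time, so the compounds shown leave open which of these two differences goes with the rise. A plain phenyl group on the same carbon would separate the two, and a 4-methoxyphenyl or 4-aminophenyl group would show whether the rise depends on the nitro group itself.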